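Working notes on a para substituent swap

This account rests on a few compounds, and the source may have more. Where it says the series, first, only, none or still open, it means among the compounds named here.

Measured in a functional assay on HeLa cells (Homo sapiens) for inhibition, read by cell counting, with a stated time of 4 days; on this read-out lower numbers stand for stronger inhibition and higher numbers for weaker inhibition:
compound 1 `C=C(Br)C(=O)Nc1cccc(-c2cn3nc(CCc4ccccc4)sc3n2)c1`: 3300 nM
compound 2 `C=C(Br)C(=O)Nc1cccc(-c2cn3nc(-c4ccc(F)cc4)sc3n2)c1`: 870 nM

Among the compounds with values here, compound 2 holds the lower of the two numbers; the only step so far is a 3.8-fold lower number from compound 1 to compound 2 (0.58 log units; beyond the scatter), which exchanged the whole phenethyl chain for 4-fluorophenyl rather than altering a single substituent on a ring already in place. Compound 3 `C=C(Br)C(=O)Nc1cccc(-c2cn3nc(-c4ccc(OC)cc4)sc3n2)c1` differs from compound 2 by methoxy in place of fluoro on an aromatic carbon. Within the data shown here, no measured pair varies just this group on the aromatic carbon, so the one step available speaks only indirectly: it shows that what sits on the shared core matters, not how methoxy compares with fluoro. With nothing pointing in either direction, compound 3 is expected to stay close to compound 2, and a 1.1-fold higher number from compound 2 to compound 3 (0.06 log units; within the scatter) is expected to remain within the scatter. The estimate for compound 3 in this assay is 1000 nM, in the range 400 nM to 3000 nM.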

Compound 3, half-maximal inhibitory concentration: 2300 nM
Beside the measured number, compound 3's estimate is 2.3-fold (0.36 log units) below it; the range from low to high includes it.
By their numbers in this assay, from the lowest: compound 2; then compounds 3 and 1 (each within the scatter of the next).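

In this assay, the aromatic carbon para to a large group responds to a change of a single substituent: methoxy in place of fluoro gives a step beyond the scatter (a 2.6-fold higher number from compound 2 to compound 3 (0.42 log units; beyond the scatter)). The gain seen on leaving phenethyl therefore does not come from any 4-substituted phenyl alone, since 4-methoxyphenyl in place of phenethyl stays within the scatter (a 1.4-fold lower number from compound 1 to compound 3 (0.16 log units; within the scatter)) and leaves compound 1 and compound 3 unordered. Among these compounds, only the 4-fluorophenyl of compound 2 stands apart from phenethyl.

Going by these compounds, with just fluoro and methoxy at this carbon, no trend can be drawn, and how chloro, an amine or a carboxylic acid would read there remains open. No evidence at hand accounts for the gap between fluoro and methoxy.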